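Working notes: carboxy in place of trifluoromethyl

A few compounds are considered here, and "the series" means these few. Any claim that something is new, unique, unknown or untested is made for them only; others in the source may bear on it.

Of the compounds shown here, three of the shared core have been measured in an assay (Rattus norvegicus) for binding affinity to prostacyclin receptor (Homo sapiens), read by radioligand binding; on this read-out lower numbers stand for stronger inhibition and higher numbers for weaker inhibition. Compound 1 `Clc1ccc(Sc2ccc(NC3=NCCN3)cc2)cc1` gives 79.4 nM. Compound 2 `CCOc1ccc(Sc2ccc(NC3=NCCN3)cc2)cc1` gives 39.8 nM. Compound 3 `FC(F)(F)c1ccc(Sc2ccc(NC3=NCCN3)cc2)cc1` gives 50.1 nM. The steps among them are all small: a 2.0-fold lower number from compound 1 to compound 2 (0.30 log units; within the scatter), a 1.6-fold lower number from compound 1 to compound 3 (0.20 log units; within the scatter) and a 1.3-fold higher number from compound 2 to compound 3 (0.10 log units; within the scatter). Compound 3 thus sits within the scatter of both other compounds, and no ordering among the three can be stated.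

The next compound, compound 4 `O=C(O)c1ccc(Sc2ccc(NC3=NCCN3)cc2)cc1`, differs from compound 3 in one place: carboxy in place of trifluoromethyl on an aromatic carbon. The measured steps that bear on this change are the three exchanges of the group at the same place, each within the scatter. None of them brings in a carboxy group, so this change reaches outside the measured range of variation. Resting on compound 1, compound 2 and compound 3, no step beyond the scatter in this assay is expected, but the range must be kept wide. The estimate for compound 4 in this assay is 79 nM, between 20 nM and 400 nM. This estimate means that the step of a 1.6-fold higher number from compound 3 to compound 4 (0.20 log units; within the scatter) is expected to remain within the scatter.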

Compound 4, inhibition constant: < 10000 nM
Compound 4 ended at the assay's limit; the forecaster's own chance of this, stated with the estimate: 5%; the middle value does not contradict the limit.
By their numbers in this assay, from the lowest: compounds 2, 3 and 1 (each within the scatter of the next).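

In this assay compound 4 gives < 10000 nM, which is a limit of the assay and not a number. No new step can be read from compound 1, compound 2 or compound 3 to compound 4: the limit of < 10000 nM in this assay, at which 1 of the 4 values shown sits.

The compounds shown leave open how large the step is when carboxy replaces chloro, ethoxy or trifluoromethyl in this assay.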